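Fluoro on the benzyl ring in a dihydropyrimidine amide series

A few compounds are considered here, and "the series" means these few. Any claim that something is new, unique, unknown or untested is made for them only; others in the source may bear on it.

Working notes on three measured compounds and one still open. Compound 1 `CC1=C(C(=O)Nc2ccc(F)cc2)C(c2ccc([N+](=O)[O-])cc2)N=C(SCc2ccc(F)cc2)N1`, compound 2 `CC1=C(C(=O)Nc2ccc([N+](=O)[O-])cc2)C(c2ccc(Br)cc2)N=C(SCc2ccccc2)N1` and compound 3 `CC1=C(C(=O)Nc2ccc([N+](=O)[O-])cc2)C(c2cccc([N+](=O)[O-])c2)N=C(SCc2ccccc2)N1` were all run in a functional assay on the whole organism (artery, strain albino) with Rattus norvegicus as the target, with a stated time of 600 min, at a dose of 10 mg/kg by the oral route; a higher number here means more inhibition at the dose given (going by the name of the read-out), a lower number less inhibition. Compound 1 gives 25.6%, compound 2 gives 27.2% and compound 3 gives 27.2%. Compound 3 is level with compound 2 at the digits given, and the two together hold the highest of the three numbers; the step of no change at the digits printed from compound 2 to compound 3 (within the scatter) is within the scatter, and the gap to compound 1 is also within the scatter, so none of the three can be told apart on these numbers.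

The next compound, compound 4 `CC1=C(C(=O)Nc2ccc([N+](=O)[O-])cc2)C(c2cccc([N+](=O)[O-])c2)N=C(SCc2ccc(F)cc2)N1`, differs from compound 3 only by fluoro in place of hydrogen on an aromatic carbon, placed on the benzylsulfanyl group para to a large group. Among the measured compounds shown here, no measured pair isolates this change: compound 1 carries the 4-fluorobenzyl but differs from compound 3 in the amide aryl and in the aryl on the saturated ring carbon as well. For the measured compounds named here, the single measured step, from compound 2 to compound 3, was flat. With every measured number sitting within the scatter of every other, the step of a number 0.2 percentage points lower from compound 3 to compound 4 (within the scatter) is expected to stay within the scatter too. Compound 4 is therefore estimated at 27% in this assay, with a range from 14% to 40%.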

Compound 4, a percentage reported as inhibition, in the whole organism at one dose (the size of the read-out at that dose, not a potency): 30.3%
Beside the measured number, compound 4's estimate is 3.3 percentage points below it; the measured number falls inside the stated range.
By their numbers in this assay, from the lowest: compounds 1, 2, 3 and 4 (each within the scatter of the next).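

In this assay the change from phenyl to 4-fluorophenyl on the benzylsulfanyl group can now be read on its own, and the step is a number 3.1 percentage points higher from compound 3 to compound 4 (within the scatter). The earlier compounds shown here offered no pair that isolated this change, whereas this pair shows that, with the amide aryl and the aryl on the saturated ring carbon held fixed, fluoro in place of hydrogen on this aromatic carbon, para to a large group, leaves the read-out within the scatter, so the two compounds cannot be told apart at this single dose. Nothing available bears on what lies behind this result.

The compounds shown leave open whether this aromatic carbon can move the read-out at all, since a single fluoro is the only replacement of hydrogen that can be read here, and a chloro, a methoxy, an amine or a carboxylic acid at the same carbon would test the position more widely. Going by these compounds, it also remains open whether the same replacement reads the same way with a different aryl on the saturated ring carbon or on the amide, as with the 4-bromophenyl of compound 2.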